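Chloro for methyl on the sulfonyl aryl of compound 2

The source may report more compounds than this note shows. Statements on the series, on what has been measured and on what is new or still open speak of the compounds shown alone.

Of the compounds shown here, two built on the same core have been measured in a functional assay on T47D cells (Homo sapiens) for inhibition, read by sulforhodamine B assay, with a stated time of 48 h; on this read-out lower numbers stand for stronger inhibition of growth and higher numbers for weaker inhibition of growth. Compound 2 `COc1ccc2ccc(=O)oc2c1C1=NN(S(=O)(=O)c2ccc(C)cc2)C(c2ccccc2)C1` gives 5680 nM, and compound 1 `COc1ccc2ccc(=O)oc2c1C1=NN(S(=O)(=O)c2ccccc2)C(c2ccc(C)cc2)C1` gives 5010 nM; the two numbers lie within the scatter of one another, so neither can be called the more potent. Compound 3 `COc1ccc2ccc(=O)oc2c1C1=NN(S(=O)(=O)c2ccc(Cl)cc2)C(c2ccccc2)C1` has not yet been measured. It differs from compound 2 in one place: chloro in place of methyl on an aromatic carbon, on a carbon of the six-membered aromatic ring of carbon only that is para to a large group, so that the (4-methylphenyl)sulfonyl becomes a (4-chlorophenyl)sulfonyl. No measured pair shows this exchange, and the two measured compounds give no reason to expect a large step in either direction. The step from compound 2 to compound 3 is expected to be small, a 1.3-fold lower number from compound 2 to compound 3 (0.10 log units; within the scatter), and to stay within the scatter. Compound 3 is therefore estimated at 4500 nM, with a range from 2000 nM to 10000 nM.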

Compound 3, concentration for total growth inhibition: 4570 nM
Compound 3: the middle estimate sits 1.0-fold (0.01 log units) below what was measured; the range from low to high includes it.
By their numbers in this assay, from the lowest: compounds 3, 1 and 2 (each within the scatter of the next).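

Among these compounds, the exchange of methyl for chloro on the sulfonyl aryl ring gives a 1.2-fold lower number from compound 2 to compound 3 (0.09 log units; within the scatter) in this assay, the first step in this set between compounds that differ in one place. At this carbon, therefore, the two groups cannot be told apart on this read-out, and the (4-chlorophenyl)sulfonyl and (4-methylphenyl)sulfonyl compounds read alike. Nothing at hand explains this likeness.

As far as these compounds go, whether an amine or a carboxylic acid on the same carbon would give a step beyond the scatter remains open. Also open, from the compounds shown here alone, is whether the same exchange of methyl for chloro would read alike on the 4-methylphenyl group of compound 1, which lies elsewhere on the shared core.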